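The source may hold more compounds than are shown below. What is called first, only, known or untested is meant among the compounds shown, and "the series" means these compounds.

Among the measured compounds shown here, compound 1 `COc1cc2c(Oc3ccc(NC(=O)c4nn(-c5ccc([N+](=O)[O-])cc5)c(=O)c5ccccc45)cc3F)ccnc2cc1OCCCN1CCCCC1` is one of two compounds measured so far in a functional assay on MDA-MB-231 cells (Homo sapiens) for cytotoxicity, read by MTT assay, with a stated time of 72 h (a higher number here means a weaker inhibitor, a lower number a stronger inhibitor), where compound 1 gives 2620 nM. For the measured compounds named here, its sole measured neighbour is compound 2 `COc1ccc(-n2nc(C(=O)Nc3ccc(Oc4ccnc5cc(OCCCN6CCCCC6)c(OC)cc45)c(F)c3)c3ccccc3c2=O)cc1`, which in this assay gives 2010 nM. The step of a 1.3-fold lower number from compound 1 to compound 2 (0.12 log units; within the scatter), a methoxy in place of nitro on an aromatic carbon, leaves the two numbers within the scatter of each other, so compound 1 and compound 2 cannot be set apart on the numbers shown.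

Compound 3 `COc1cc2c(Oc3ccc(NC(=O)c4nn(-c5ccc([N+](=O)[O-])cc5)c(=O)c5ccccc45)cc3F)ccnc2cc1OCCCN1CCC(C)CC1` differs from compound 1 by methyl in place of hydrogen on a saturated ring carbon, the methyl sitting three ring bonds from the ring nitrogen. Going by the values given here, no measured step touches this saturated ring: the only step available, a 1.3-fold lower number from compound 1 to compound 2 (0.12 log units; within the scatter), concerns the aromatic substituent at the other end of the shared core and gives no direct guide to a methyl on the piperidine. Among the compounds with values here, since the single measured change left the read-out within the scatter, a small change of this kind is likewise expected to stay within the scatter. Compound 3 is therefore estimated to give 2500 nM in this assay, with a range from 1000 nM to 6500 nM. This estimate means an expected step of a 1.0-fold lower number from compound 1 to compound 3 (0.02 log units; within the scatter), not beyond the scatter.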

Compound 3, half-maximal inhibitory concentration: 4010 nM
Estimate against measurement, compound 3: 1.6-fold (0.21 log units) below; the measured number falls inside the stated range.
By their numbers in this assay, from the lowest: compounds 2, 1 and 3 (each within the scatter of the next).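

In this assay, among the compounds shown here, the change from piperidin-1-yl to 4-methylpiperidin-1-yl gives a 1.5-fold higher number from compound 1 to compound 3 (0.18 log units; within the scatter) and is the first measured step at this saturated ring, as the earlier step concerned only the aromatic substituent at the other end of the shared core. It shows that a methyl on this ring carbon, three ring bonds from the ring nitrogen, leaves the read-out within the scatter on the core of compound 1, so on these numbers compound 1 and compound 3 cannot be set apart, just as compound 1 and compound 2 could not be. No measurement of any property bears on this result, and nothing can be said about what lies behind it.

On these data alone, whether a larger group on the same ring carbon, such as phenyl, or a polar one, such as hydroxyl, would carry the number beyond the scatter remains open, as does the outcome of replacing piperidin-1-yl with morpholin-4-yl or 4-methylpiperazin-1-yl. The compounds shown also leave open whether the same methyl would give a similar step on compound 2, which carries methoxy in place of nitro.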